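A few compounds are considered here, and "the series" means these few. Any claim that something is new, unique, unknown or untested is made for them only; others in the source may bear on it.

Measured compounds:
- compound 1 `Cc1cc2cc(NS(=O)(=O)c3cc(C(=O)NO)ccc3Cl)ccc2n(C)c1=O`: 32%
- compound 2 `Cc1cc2cc(NS(=O)(=O)Cc3ccc(C(=O)NO)cc3)ccc2n(C)c1=O`: 0%

In a functional assay on HL-60 cells (Homo sapiens) for antiproliferative activity, tested at 20 uM (a lower number here means a weaker effect, a higher number a stronger effect of the compound at the concentration tested), compound 1 gives 32%, the higher of the two numbers. Compound 2 gives 0%, a number lower by more than the usual scatter. These two compounds differ in several places at once, so their values can only be set side by side, and no single change can be read from them.

Compound 3 `COc1ccc(C(=O)NO)cc1S(=O)(=O)Nc1ccc2c(c1)cc(C)c(=O)n2C` has not yet been measured. It follows from compound 1 by one change: methoxy in place of chloro on an aromatic carbon. Within the data shown here, no measured pair shows what this exchange does, so the expectation rests on compound 1 alone. Because compound 1 gives 32% and the rest of the molecule is unchanged, compound 3 is expected to land nearby. The step of a number 6 percentage points lower from compound 1 to compound 3 (within the scatter) is expected to be small, within the scatter or slightly downward. The estimate for compound 3 is 26%, with a range from 5% to 48%.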

Compound 3, a percentage reported as inhibition, at one concentration (the size of the read-out at that concentration, not a potency): 10%
For compound 3 the middle estimate is 16 percentage points above the measured one, and the stated range covers the measured number.
By their numbers in this assay, from the lowest: compounds 2 and 3 (each within the scatter of the next); then compound 1.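

In this assay, among these compounds, this is the first single change that can be read: methoxy in place of chloro, on the aromatic carbon para to a hydroxycarbamoyl group, gives a number 22 percentage points lower from compound 1 to compound 3 (beyond the scatter). The position is therefore not indifferent to what it carries, since the rest of the molecule stays the same and the read-out at this one concentration still falls by more than the usual scatter. No available measurement bears on what lies behind this step.

The compounds shown leave open whether chloro helps here or methoxy harms, and a plain hydrogen, a fluoro or a methyl group on this same carbon would help separate those two readings. Also open, from the compounds shown here alone, is whether this step reflects a change in potency, which a read-out at a single concentration cannot show.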